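Swapping chloro for methoxy on the anilino ring of compound 3

This account rests on a few compounds, and the source may have more. Where it says the series, first, only, none or still open, it means among the compounds named here.

Of the compounds shown here, three sharing one core have been measured in a functional assay on the whole organism (strain Wister albino) for inhibition, with Rattus norvegicus as the target, read by paw edema, with stated times of 1 h and 4 h, at a dose of 50 mg/kg by the intraperitoneal route; on this read-out lower numbers stand for less inhibition and higher numbers for more inhibition at the one dose given (going by the name of the read-out). Compound 1 `CCOC(=O)c1c(-c2ccc(Cl)cc2)cc(-c2ccccc2)nc1Nc1ccc(OC)cc1` gives 38.9% in this assay. Compound 2 `CCOC(=O)c1c(-c2ccc(C)cc2)cc(-c2ccccc2)nc1N1CCCCC1` gives 78%, and compound 3 `CCOC(=O)c1c(-c2ccc(C)cc2)cc(-c2ccccc2)nc1Nc1ccc(Cl)cc1` gives 79.4%. Compound 3 holds the highest number of the three: the step of a number 1.4 percentage points higher from compound 2 to compound 3 (within the scatter) is within the scatter, while compound 1 lies beyond the scatter below it. Among the measured compounds shown here, the one measured single change, a number 1.4 percentage points higher from compound 2 to compound 3 (within the scatter), concerns the group on the aromatic carbon of the core and shows no effect beyond the scatter.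

Compound 4 `CCOC(=O)c1c(-c2ccc(C)cc2)cc(-c2ccccc2)nc1Nc1ccc(OC)cc1` is not yet measured. It differs from compound 3 by methoxy in place of chloro on an aromatic carbon. For the measured compounds named here, no measured step bears directly on this change. Going by the values given here, compound 1, which also carries the (4-methoxyphenyl)amino group but differs elsewhere too, shows only that a compound with this group can sit well below compound 3. Because compound 1 gives 38.9%, a drop is expected, of about a number 21.4 percentage points lower from compound 3 to compound 4 (beyond the scatter). Compound 4 is therefore estimated at 58%, ranging from 40% to 76%.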

Compound 4, a percentage reported as inhibition, in the whole organism at one dose (the size of the read-out at that dose, not a potency): 89.4%
The estimate for compound 4 lay 31.4 percentage points below the measured number; measured number above the stated range.
By their numbers in this assay, from the lowest: compound 1; then compounds 2, 3 and 4 (each within the scatter of the next, the first and the last beyond it).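

On the aromatic carbon para to a large group, methoxy in place of chloro leaves this assay without a change beyond the scatter (a number 10 percentage points higher from compound 3 to compound 4 (within the scatter)). Against piperidin-1-yl, however, (4-methoxyphenyl)amino now gives a modest step beyond the scatter (a number 11.4 percentage points higher from compound 2 to compound 4 (beyond the scatter)), which (4-chlorophenyl)amino did not give. The (4-methoxyphenyl)amino group is also compatible with a high number, since with this group held constant, methyl in place of chloro on the other aromatic carbon gives a large step (a number 50.5 percentage points higher from compound 1 to compound 4 (beyond the scatter)).

Still open, on these data alone, is whether an amine, a hydroxyl or a longer alkoxy chain on this ring, or a carboxylic acid in place of the ethyl ester, would keep the number this high. Nothing shown here explains why these steps differ in size.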